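The source may hold more compounds than are shown below. What is called first, only, known or untested is meant among the compounds shown, and "the series" means these compounds.

Compound 1 `COc1cncc(-c2ccnc3c2c(C(C)C)nn3-c2ccc(C(N)=O)c(N[C@H]3CC[C@H](O)CC3)c2)c1` and compound 2 `CC(C)c1nn(-c2ccc(C(N)=O)c(N[C@H]3CC[C@H](O)CC3)c2)c2nccc(-c3cccnc3)c12` share one core and differ in a single place: hydrogen in place of methoxy on an aromatic carbon. In a functional assay on SK-BR-3 cells (Homo sapiens) for inhibition, read by CellTiter-Glo, with a stated time of 72 h (a higher number here means a weaker inhibitor, a lower number a stronger inhibitor), compound 1 gives 451 nM, and compound 2 gives 464 nM; the step of a 1.0-fold higher number from compound 1 to compound 2 (0.01 log units; within the scatter) is the only measured yardstick for this change. Compound 3 `COc1ccc(-c2cn(-c3ccnc4c3c(C(C)C)nn4-c3ccc(C(N)=O)c(N[C@H]4CC[C@H](O)CC4)c3)cn2)cc1` carries a different group on the shared core; how its core differs from that of compound 1 is not broken down here. In this assay compound 3 gives 256 nM. Compound 4 `CC(C)c1nn(-c2ccc(C(N)=O)c(N[C@H]3CC[C@H](O)CC3)c2)c2nccc(-n3cnc(-c4ccccc4)c3)c12` differs from compound 3 by the same kind of change, (hydrogen in place of methoxy on an aromatic carbon), but the methoxy now leaves a six-membered aromatic ring of carbon only, para to a large group, rather than a ring with 1 nitrogen, two atoms from the ring nitrogen, meta to a large group. Because the earlier step of a 1.0-fold higher number from compound 1 to compound 2 (0.01 log units; within the scatter) stayed within the scatter, compound 4 is expected to move from compound 3 by a 1.2-fold higher number from compound 3 to compound 4 (0.07 log units; within the scatter). Compound 4 is therefore estimated at 300 nM, most likely between 140 nM and 650 nM.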

Compound 4, half-maximal inhibitory concentration: 276 nM
Compound 4: middle estimate off by 1.1-fold (0.04 log units), on the high side; low and high end bracket the measured number.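

Putting hydrogen in place of methoxy gives a 1.1-fold higher number from compound 3 to compound 4 (0.03 log units; within the scatter) in this assay, so the change leaves the number essentially unmoved on both cores: the same change on two cores in this assay, a 1.0-fold higher number (0.01 log units; within the scatter) from compound 1 to compound 2 and a 1.1-fold higher number (0.03 log units; within the scatter) from compound 3 to compound 4, 1.0-fold (0.02 log units) apart, within the scatter of two such steps Exchanging the larger group on the shared core also stays small, with a 1.7-fold lower number from compound 2 to compound 4 (0.23 log units; within the scatter) and a 1.6-fold lower number from compound 1 to compound 4 (0.21 log units; within the scatter). Going by these compounds alone, this shows only that the methoxy change had no measurable effect in two pairs, with the methoxy on a different ring in each, and it does not show that the same would hold on every core.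

Going by these compounds, it remains open whether a different group in the methoxy position, such as an amine or a carboxylic acid, would move the number beyond the scatter. A third core could also behave differently.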